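The source may report more compounds than this note shows. Statements on the series, on what has been measured and on what is new or still open speak of the compounds shown alone.

Measured compounds:
compound 1 `O=C1O[C@H]([C@@H](O)Cn2cc(CNS(=O)(=O)c3ccc(Cl)cc3)nn2)C(OCc2ccccc2)=C1OCc1ccccc1`, 2870 nM
compound 2 `CCCCCCCCCCc1cn(C[C@H](O)[C@H]2OC(=O)C(OCc3ccccc3)=C2OCc2ccccc2)nn1`, 6750 nM

In a functional assay on A549 cells (Homo sapiens) for antiproliferative activity, read by MTT assay, with a stated time of 72 h (a lower number here means a stronger inhibitor, a higher number a weaker inhibitor), compound 2 holds the highest number of the two; compound 1 lies lower by a 2.4-fold higher number from compound 1 to compound 2 (0.37 log units; beyond the scatter). Compound 3 `O=C1O[C@H]([C@@H](O)Cn2ccnn2)C(OCc2ccccc2)=C1OCc1ccccc1` differs from compound 2 by hydrogen in place of decyl on an aromatic carbon. For the measured compounds named here, the one measured step exchanges one side chain for another and only loosely bears on removing the decyl altogether. The step is expected to be a 1.3-fold higher number from compound 2 to compound 3 (0.12 log units; within the scatter), with direction uncertain and the range wide. Compound 3 is estimated at 9000 nM, between 3000 nM and 30000 nM.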

Compound 3, half-maximal inhibitory concentration: > 100000 nM
Compound 3: no number, only a limit; the forecaster's own chance of this, stated with the estimate: 20%; at least 11-fold (1.04 log units) between middle value and limit.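

In this assay compound 3 stands only as a limit of the assay, not as a number: the limit of > 100000 nM in this assay, at which 1 of the 3 values shown sits. Hydrogen in place of decyl on this aromatic carbon gives an at least 14-fold higher number from compound 2 to compound 3 (1.17 log units; beyond the scatter), and hydrogen in place of (((4-chlorophenyl)sulfonyl)amino)methyl gives an at least 34-fold higher number from compound 1 to compound 3 (1.54 log units; beyond the scatter). Two quite different groups on this carbon both give a measured value, so having a group there counts for more than which of these two it is. Still open, on these data alone, is how small that group can be, for example methyl or a butyl chain, and whether a chain ending in an amine or a carboxylic acid serves as well.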